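This account rests on a few compounds, and the source may have more. Where it says the series, first, only, none or still open, it means among the compounds named here.

Measured compounds:
compound 1, `CC(C)CCn1c(N2CCN(C)CC2)nc2ccccc21`, 1400 nM
compound 2, `CCCCCN1CCN(c2nc3ccccc3n2CCOCC)CC1`, 30 nM

In a functional assay on ileum for inhibition of histamine H1 receptor (Cavia porcellus) (on this read-out lower numbers stand for stronger inhibition and higher numbers for weaker inhibition), compound 1 gives 1400 nM and compound 2 gives 30 nM. Compound 1 thus stands at the higher of the two numbers, and compound 2 sits well beyond the scatter from it; the two compounds differ in more than one place, so their values are shown side by side without a single step being drawn between them. Compound 3, `CCCn1c(N2CCN(C)CC2)nc2ccccc21`, has not yet been measured. It differs from compound 1 by methyl in place of isopropyl on a saturated chain carbon, two bonds along the chain from an aromatic nitrogen. Among the measured compounds shown here, no pair of measured compounds shows what this particular change does, so the step from compound 1 to compound 3 in this assay is expected to be small, with no clear direction, and is estimated at a 1.4-fold higher number from compound 1 to compound 3 (0.15 log units; within the scatter). Compound 3 is therefore expected to give about 2000 nM, within a range of 600 nM to 6000 nM.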

Compound 3, half-maximal inhibitory concentration: 380 nM
The estimate for compound 3 lay 5.3-fold (0.72 log units) above the measured number; measured number below the stated range.
By their numbers in this assay, from the lowest: compound 2; then compound 3; then compound 1.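

In this assay, the change of methyl in place of isopropyl on a saturated chain carbon, two bonds along the chain from an aromatic nitrogen, turns isopentyl into propyl and gives a 3.7-fold lower number from compound 1 to compound 3 (0.57 log units; beyond the scatter). This shows that the position is not indifferent to the change: the branched end of the isopentyl chain of compound 1 is not needed for inhibition in this pair, and its removal gives a step beyond the usual scatter. Nothing available explains why the number falls with this change.

This single step does not establish a trend with chain length. From the compounds shown here alone, it remains open how a shorter ethyl, a butyl, or a chain ending in a hydroxyl group or a carboxylic acid would behave at this place on the shared core.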